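Removing the aryl methyl: compound 3 to compound 4

The compounds below may be only part of what the source reports. "The series", "measured", "known", "first", "only" and "open" are said of these compounds alone.

Compound 3 `CCC(C(=O)N1CCN(c2cccc(C)c2)CC1)N1C(=O)CCC1=O` stands at 0% in a functional assay on the whole organism (strain Swiss) with Mus musculus as the target, in the maximal electroshock model, with a stated time of 0.5 h, at a dose of 100 mg/kg by the intraperitoneal route; on this read-out lower numbers stand for a weaker effect and higher numbers for a stronger effect at the one dose given. Compound 1 `CC(C(=O)N1CCN(c2ccccc2)CC1)N1C(=O)CCC1=O` gives 0% in this assay, and compound 2 `CCC(C(=O)N1CCN(c2cccc(F)c2)CC1)N1C(=O)CCC1=O` gives 0%; compound 3 is level with both at the digits shown, nearest compound 1 and furthest compound 2, and no step among the three lies beyond the scatter.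

The step to compound 4 `CCC(C(=O)N1CCN(c2ccccc2)CC1)N1C(=O)CCC1=O` is hydrogen in place of methyl on an aromatic carbon; the same difference, cut one bond further out, reads 3-methylphenyl to phenyl.

Among the compounds with values here, only one measured step touches the same aromatic position: no change at the digits printed from compound 2 to compound 3 (within the scatter) for methyl in place of fluoro on an aromatic carbon. Swapping substituents there left the read-out unmoved. Within the data shown here, compound 1, which already carries an unsubstituted phenyl on the shared core, shows 0%, the same number as compound 3 with its 3-methylphenyl; no single-point step between compound 1 and compound 4 is computed, so only the two values themselves are compared. Nothing in the series indicates that removing the methyl would lift activity in this assay.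

Compound 4 is therefore expected at 0%, with a range of 0% to 10%. The expected step is no change at the digits printed from compound 3 to compound 4 (within the scatter), none beyond the scatter.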

Compound 4, a percentage reported as activity, at one dose (the size of the read-out at that dose, not a potency): 25%
Beside the measured number, compound 4's estimate is 25 percentage points below it; measured number outside the range, above it.
By their numbers in this assay, from the lowest: compounds 1, 2 and 3 (each within the scatter of the next); then compound 4.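

In this assay, the aromatic position is no longer silent: a number 25 percentage points higher from compound 3 to compound 4 (beyond the scatter) for hydrogen in place of methyl, and a number 25 percentage points higher from compound 2 to compound 4 (beyond the scatter) for hydrogen in place of fluoro, so a response appears with the plain phenyl although exchanging fluoro for methyl had given no change at the digits printed from compound 2 to compound 3 (within the scatter). Within these compounds the contrast is therefore between hydrogen and either of the two substituents, and the saturated chain carbon also counts, with a number 25 percentage points higher from compound 1 to compound 4 (beyond the scatter) for methyl in place of hydrogen, two bonds along the chain from an amide-type nitrogen in a ring and a carbonyl carbon. No measurement at hand accounts for these steps.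

Open, as far as these compounds go, is whether any other aromatic substituent, such as chloro or methoxy, keeps the response seen with hydrogen, or whether a methyl or fluoro placed elsewhere on the ring behaves as these do. Also open, from the compounds shown here alone, is whether a longer chain, such as propyl, on the saturated chain carbon carries the response further, and how the read-out at this one dose would relate to potency.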